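The compounds below may be only part of what the source reports. "The series", "measured", "known", "first", "only" and "open" are said of these compounds alone.

Measured compounds:

Compound 1, `COc1cccc(N2C(=O)CS/C2=N\c2csc(-c3ccc(C)cc3)c2)c1`, gives 41000 nM in a functional assay on HCT-116 cells (Homo sapiens) for cytotoxicity, read by MTT assay, with a stated time of 72 h; a higher number here means a weaker inhibitor, a lower number a stronger inhibitor.
Compound 2, `COc1ccc(-c2cc(/N=C3\SCC(=O)N3c3cccc(OC)c3)cs2)cc1`, gives 2700 nM in this assay.
Compound 3, `Cc1ccc(/C=C2\S/C(=N\c3nc(-c4ccc(Cl)cc4)cs3)NC2=O)cc1`, gives 500 nM in this assay.

Compound 1 and compound 2 share one core and differ in a single place: methoxy in place of methyl on an aromatic carbon. That single change made a large step, a 15-fold lower number from compound 1 to compound 2 (1.18 log units; beyond the scatter), so the methoxy compound is the stronger of the two by a margin beyond the scatter.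

Compound 3 sits on a different core. The difference between the core of compound 1 and the core of compound 3 is not broken down here; among the three measured compounds, compound 3 gives the lowest number, and its gap to compound 2 and to compound 1 lies beyond the scatter in each case.

Compound 4, `COc1ccc(/C=C2\S/C(=N\c3nc(-c4ccc(Cl)cc4)cs3)NC2=O)cc1`, has not yet been measured. It differs from compound 3 in one place: methoxy in place of methyl on an aromatic carbon. This is the same change that carried compound 1 to compound 2, made at a place described in the same words. On that basis compound 4 is expected to give a lower number than compound 3, an estimated step of a 2.9-fold lower number from compound 3 to compound 4 (0.47 log units; beyond the scatter), though smaller than the earlier one, because a 15-fold lower number from compound 1 to compound 2 (1.18 log units; beyond the scatter) was seen on a different core and one pair is a thin basis. Compound 4 is expected to give about 170 nM, likely between 50 nM and 600 nM.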

Compound 4, half-maximal inhibitory concentration: 400 nM
Estimate against measurement, compound 4: 2.4-fold (0.37 log units) below; measured number inside the range.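

In this assay, putting methoxy in place of methyl on the core of compound 3, which turns 4-methylphenyl into 4-methoxyphenyl, gives a 1.3-fold lower number from compound 3 to compound 4 (0.10 log units; within the scatter), so these two compounds cannot be told apart here. Set beside the earlier step, the same change did not keep its size when carried from one core to the other: the same change on two cores in this assay, a 15-fold lower number (1.18 log units; beyond the scatter) from compound 1 to compound 2 and a 1.3-fold lower number (0.10 log units; within the scatter) from compound 3 to compound 4, 12-fold (1.08 log units) apart, beyond the scatter of two such steps. Among the compounds shown here, this shows that the large step seen on the core of compound 1 cannot be assumed on the core of compound 3, but with only one pair on each core it does not show why the two steps differ or what the change would do on a further core.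

The compounds shown leave open whether an amine, a carboxylic acid or a longer chain on the same aromatic carbon would shift the number on the core of compound 3. They also leave open whether the gap between the two steps would appear in any assay other than this assay.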